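Hydroxy for dimethylamino: notes on a small inhibitor series

A few compounds are considered here, and "the series" means these few. Any claim that something is new, unique, unknown or untested is made for them only; others in the source may bear on it.

Within the data shown here, in a functional assay (Homo sapiens) for inhibition (a lower number here means a stronger inhibitor, a higher number a weaker inhibitor), compound 1 (`COc1cc(O)cc(C)c1/C=C/C(=O)c1ccc(O)cc1`) gives 53000 nM while compound 3 (`C=CCOc1ccc(C(=O)/C=C/c2cc(OC)c(CCCCCC)c(OC)c2)cc1`) gives 15000 nM as the two higher numbers so far. Compound 2 (`COc1cc(/C=C/C(=O)c2ccccc2N(C)C)cc(OC)c1`) has the lowest number of the three (5700 nM) and stands clear of both others beyond the scatter, with compound 3 the nearer of the two.

The next compound is compound 4 (`COc1cc(/C=C/C(=O)c2ccccc2O)cc(OC)c1`), which carries hydroxy in place of dimethylamino on an aromatic carbon ortho to a large group. Among the measured compounds shown here, no measured pair isolates this change, and the measured compounds differ from one another in several places at once, so any guide is indirect. For the measured compounds named here, compound 2 is the only measured compound with dimethylamino. Compound 3 at 15000 nM and compound 1 at 53000 nM both lack that group and both show higher numbers, which is a weak hint from very few compounds, and none of the three goes against it. A small rise toward a weaker inhibitor is therefore expected, with an estimated 1.8-fold higher number from compound 2 to compound 4 (0.24 log units; within the scatter) as the likeliest outcome. Compound 4 is expected at 10000 nM (estimated range 3500 nM to 30000 nM).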

Compound 4, half-maximal inhibitory concentration: 8100 nM
Beside the measured number, compound 4's estimate is 1.2-fold (0.09 log units) above it; the measured number falls inside the stated range.
By their numbers in this assay, from the lowest: compounds 2, 4 and 3 (each within the scatter of the next, the first and the last beyond it); then compound 1.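

Among these compounds, compound 2 and compound 4 form the first pair that differs in one place only, which gives a direct reading of this position in this assay: hydroxy in place of dimethylamino on an aromatic carbon ortho to a large group gives a 1.4-fold higher number from compound 2 to compound 4 (0.15 log units; within the scatter), and this step lies within the scatter. The earlier compounds shown here differ in several places at once and offered only a weak hint tied to dimethylamino, whereas this pair shows that 3 heavy atoms with 0 hydrogen-bond donors and 1 heavy atom with 1 hydrogen-bond donor cannot be told apart here, so the reading of compound 2 does not depend on dimethylamino at this position. Nothing available accounts for this result, and no cause can be assigned to it.

The compounds shown leave open whether this position accepts other groups in the same way, such as a carboxylic acid, a primary amine or a longer chain. Going by these compounds, it also remains open whether the same exchange would read alike on the core of compound 1 or the core of compound 3, as one pair on one core cannot settle that.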